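Working notes: from compound 2 to compound 3

This account rests on a few compounds, and the source may have more. Where it says the series, first, only, none or still open, it means among the compounds named here.

Compound 2 `COc1ccc(C(=O)CSc2nnc(Cc3ccccc3Nc3c(Cl)cccc3Cl)o2)cc1OC` gives 51.4% in a functional assay on the whole organism (strain Swiss) with Mus musculus as the target, in the writhing test, with a stated time of 25 min, at a dose of 10 mg/kg by the oral route (a higher number here means more inhibition at the dose given (going by the name of the read-out), a lower number less inhibition), the lower of the two numbers measured, while compound 1 `COc1cccc(C(=O)CSc2nnc(Cc3ccccc3Nc3c(Cl)cccc3Cl)o2)c1` gives 66.9%. Among the measured compounds shown here, the single measured step, a number 15.5 percentage points lower from compound 1 to compound 2 (beyond the scatter), is modest. Compound 3 `O=C(CSc1nnc(Cc2ccccc2Nc2c(Cl)cccc2Cl)o1)c1ccc(O)cc1` differs from compound 2 by 4-hydroxyphenyl in place of 3,4-dimethoxyphenyl on a carbonyl carbon. For the measured compounds named here, no measured step covers this change directly; the only related step, from compound 1 to compound 2, went with a methoxy group entering, and compound 3 loses both methoxy groups. A modest rise back toward compound 1 is therefore expected, a number 8.6 percentage points higher from compound 2 to compound 3 (within the scatter). Compound 3 is estimated at 60%, with a range of 45% to 75%.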

Compound 3, a percentage reported as inhibition, in the whole organism at one dose (the size of the read-out at that dose, not a potency): 68.2%
Compound 3: the middle estimate sits 8.2 percentage points below what was measured, within the range that was stated.
By their numbers in this assay, from the lowest: compound 2; then compounds 1 and 3 (each within the scatter of the next).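

In this assay, a step of a number 16.8 percentage points higher from compound 2 to compound 3 (beyond the scatter) shows that 4-hydroxyphenyl on this carbonyl carbon does not share the lower number of 3,4-dimethoxyphenyl. The step of a number 1.3 percentage points higher from compound 1 to compound 3 (within the scatter) leaves 4-hydroxyphenyl and 3-methoxyphenyl indistinguishable here, so a single oxygen-bearing phenyl group of either kind separates from the 3,4-dimethoxyphenyl of compound 2. No data at hand account for these steps.

The compounds shown leave open whether the hydroxy group itself matters or only the absence of the second methoxy group. As far as these compounds go, how an amine or a carboxylic acid in place of that hydroxy group would read also remains open.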